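The compounds below may be only part of what the source reports. "The series", "measured", "known", "first", "only" and "open" are said of these compounds alone.

Measured so far:
- compound 1 `CCOC(=O)c1cccc(-c2ccc(O)cc2)c1`, 100000 nM
- compound 2 `CCOc1ccc(-c2cccc(S(=O)(=O)N(C)C)c2)cc1`, 110000 nM

In an assay on COS-7 cells for inhibition of patatin-like phospholipase domain-containing protein 2 (Mus musculus) (on this read-out higher numbers stand for weaker inhibition and lower numbers for stronger inhibition), compound 2 gives 110000 nM, and compound 1 gives 100000 nM; the two numbers lie within the scatter of each other, so no order between them can be read. Compound 3 `CCNC(=O)c1cccc(-c2ccc(OCC)cc2)c1` has not been measured. Relative to compound 2 it carries ethylcarbamoyl in place of dimethylsulfamoyl on an aromatic carbon. Among the compounds with values here, no measured pair shows the weight of such a change here. With both measured numbers this far up the scale, the step from compound 2 to compound 3 is expected to be a 1.1-fold lower number from compound 2 to compound 3 (0.04 log units; within the scatter), none beyond the scatter. Compound 3 is therefore estimated at 100000 nM, within 40000 nM to 300000 nM.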

Compound 3, half-maximal inhibitory concentration: 90000 nM
The estimate for compound 3 lay 1.1-fold (0.05 log units) above the measured number, within the range that was stated.
By their numbers in this assay, from the lowest: compounds 3, 1 and 2 (each within the scatter of the next).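

In this assay, within the data shown here, the first measured step at this aromatic carbon is a 1.2-fold lower number from compound 2 to compound 3 (0.09 log units; within the scatter), so ethylcarbamoyl in place of dimethylsulfamoyl gives no readable change here. The exchange alters the hydrogen-bond donor and acceptor counts and removes the sulfur, yet the number stays within the scatter. No supporting measurement bears on this result.

Still open, going by these compounds, is whether a carboxylic acid or an amine on this carbon, or a longer chain in place of the ethyl of ethylcarbamoyl, would give a step beyond the scatter.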